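A few compounds are considered here, and "the series" means these few. Any claim that something is new, unique, unknown or untested is made for them only; others in the source may bear on it.

Values in a functional assay on the whole organism with Rattus norvegicus as the target; on this read-out higher numbers stand for an effect only at larger amounts of compound and lower numbers for an effect already at smaller amounts:
- compound 1 `CCN(CCNC(=O)c1cc(Cl)c(N)cc1OC)Cc1ccccc1`: 0.31 mg/kg
- compound 2 `CCN(CCNC(=O)c1cc(Cl)c(N)cc1OC)Cc1ccoc1`: 3 mg/kg
- compound 3 `COc1cc(N)c(Cl)cc1C(=O)NCCN(C)C(C)c1ccccc1`: 1 mg/kg

In this set, compound 2 at 3 mg/kg has the highest number, with both other compounds lower by more than the scatter. Next comes compound 4 `CCN(CCNC(=O)c1cc(Cl)c(N)cc1OC)Cc1ccccc1OC`, which has 2-methoxyphenyl in place of furan-3-yl on a saturated chain carbon bound to an amine nitrogen. Cut one bond further out, this reads (furan-3-yl)methyl to 2-methoxybenzyl.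

Among the measured compounds shown here, one measured step bears on this change: a 9.7-fold higher number from compound 1 to compound 2 (0.99 log units; beyond the scatter), beyond the scatter, with furan-3-yl replacing phenyl at the same place. The step to compound 4 leaves furan-3-yl for a six-membered aromatic ring of carbon only, so that step is read in reverse, and a lower number is expected. For the measured compounds named here, no measured compound carries 2-methoxyphenyl, however, so a full return to the level of compound 1 at 0.31 mg/kg cannot be assumed. Going by the values given here, no single-place step links compound 3 to the others, so it only marks the middle of the measured values. The expected change is a 4.3-fold lower number from compound 2 to compound 4 (0.63 log units; beyond the scatter), a lower number by estimate. For compound 4 the estimated value is 0.7 mg/kg, with an expected range of 0.15 mg/kg to 3 mg/kg.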

Compound 4, dose for half-maximal effect: 10 mg/kg
For compound 4 the middle estimate is 14-fold (1.15 log units) below the measured one; measured number above the stated range.
By their numbers in this assay, from the lowest: compound 1; then compound 3; then compound 2; then compound 4.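

At this position in this assay, a six-membered aromatic ring of carbon only does not by itself bring the low number: 2-methoxyphenyl in place of furan-3-yl gives a 3.3-fold higher number from compound 2 to compound 4 (0.52 log units; beyond the scatter) and so runs opposite to the direction read from the phenyl to furan-3-yl step. The methoxy in place of hydrogen on an aromatic carbon gives a 32-fold higher number from compound 1 to compound 4 (1.51 log units; beyond the scatter) and is the largest single-place step in the series so far, so among these three compounds furan-3-yl stands between phenyl and 2-methoxyphenyl, and ring type alone does not set the order. Nothing measured here accounts for this shift.

Whether the rise belongs to methoxy in particular or would also follow a fluoro or a methyl group on the same aromatic carbon stays open, since the only substituted ring shown is 2-methoxyphenyl. Also open, from the compounds shown here alone, is where a thiophene or a pyridine ring would fall in the same place on a saturated chain carbon bound to an amine nitrogen, relative to the phenyl of compound 1 at 0.31 mg/kg and to furan-3-yl.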